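Swapping a Cyclohexyl for Pyridin-3-yl on the Shared Core

The source may hold more compounds than are shown below. What is called first, only, known or untested is meant among the compounds shown, and "the series" means these compounds.

Measured so far in a functional assay on MGC-803 cells (Homo sapiens) for antiproliferative activity, read by CCK-8 assay, with a stated time of 72 h, tested at 8 uM; a higher number here means a stronger effect of the compound at the concentration tested, a lower number a weaker effect:
- compound 1, `Nc1ccccc1NC(=O)c1ccc(CSC(=S)N2CCN(C3CCCCC3)CC2)cc1`: 75.3%
- compound 2, `Nc1ccccc1NC(=O)c1ccc(CSC(=S)N2CCc3cc([N+](=O)[O-])ccc32)cc1`: 33.2%
- compound 3, `CN(Cc1cccnc1)C(=S)SCc1ccc(C(=O)Nc2ccccc2N)cc1`: 85.5%

Among these three numbers compound 1 stands second highest; compound 3 lies higher by a margin beyond the usual scatter, and compound 2 lies far lower, also beyond the scatter. Compound 4, `Nc1ccccc1NC(=O)c1ccc(CSC(=S)N2CCN(c3cccnc3)CC2)cc1`, has not yet been tested in this assay. Its change from compound 1 is pyridin-3-yl in place of cyclohexyl on an amine nitrogen in a ring. Going by the values given here, no pair of measured compounds differs in a single place, so the size of this step cannot be read from the data. The three measured compounds all keep the same core and still spread widely, so a moderate shift either way is possible. Compound 4 is expected to give about 70% in this assay, within 50% to 88%, so the expected step of a number 5.3 percentage points lower from compound 1 to compound 4 (within the scatter) stays within the scatter.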

Compound 4, a percentage reported as inhibition, at one concentration (the size of the read-out at that concentration, not a potency): 76.9%
Beside the measured number, compound 4's estimate is 6.9 percentage points below it, and the stated range covers the measured number.
By their numbers in this assay, from the lowest: compound 2; then compounds 1, 4 and 3 (each within the scatter of the next, the first and the last beyond it).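

In this assay, going by these compounds alone, the one step that can be read at this position gives a number 1.6 percentage points higher from compound 1 to compound 4 (within the scatter). On this amine nitrogen in a ring, the aromatic pyridin-3-yl and the non-aromatic cyclohexyl therefore cannot be told apart at the concentration tested. Nothing available gives a reason for this match. From the compounds shown here alone, it remains open whether a methyl group, a carboxylic acid or a longer chain on the same nitrogen would also leave the read-out within the scatter. A reading at one concentration also leaves open whether compound 1 and compound 4 match in potency.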